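The source may hold more compounds than are shown below. What is called first, only, known or untested is meant among the compounds shown, and "the series" means these compounds.

Compound 3 `C=CC(=O)Nc1cccc(Cn2nc(-c3ccc(Oc4ccccc4)cc3)cc2C(=O)OCC)c1` is the ethyl ester of the series in which the acrylamide is carried on an aniline; in a functional assay on Maver1 cells (Homo sapiens) for inhibition, read by luminescence and CellTiter-Glo, with a stated time of 72 h (a lower number here means a stronger inhibitor, a higher number a weaker inhibitor), compound 3 gives 8600 nM. Compound 2 `C/C=C/C(=O)Nc1cccc(Cn2nc(-c3ccc(Oc4ccccc4)cc3)cc2C(=O)OCC)c1` keeps that arrangement and differs only by prop-1-en-1-yl in place of vinyl on a carbonyl carbon; in this assay compound 2 gives 14200 nM, so the step of a 1.7-fold higher number from compound 3 to compound 2 (0.22 log units; within the scatter) is small.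

Compound 1 `C=CC(=O)N1CCCC(n2nc(-c3ccc(Oc4ccccc4)cc3)cc2C(=O)O)C1` carries the acrylamide on a piperidine and bears a free acid; the difference between its core and the core of compound 3 is not broken down here. In this assay compound 1 reaches only a limit, > 60000 nM, which is the limit of > 60000 nM in this assay, at which 1 of the 3 values shown sits.

Compound 4 `C/C=C/C(=O)N1CCCC(n2nc(-c3ccc(Oc4ccccc4)cc3)cc2C(=O)O)C1` stands to compound 1 as compound 2 stands to compound 3: prop-1-en-1-yl in place of vinyl on a carbonyl carbon. The surroundings are not identical, since here the carbonyl carbon sits on an amide-type nitrogen in a ring rather than on an amide-type nitrogen, so it is the same kind of change rather than the same one. Because the step of a 1.7-fold higher number from compound 3 to compound 2 (0.22 log units; within the scatter) lay within the scatter, compound 4 is expected to move by about a step that the limit leaves unreadable from compound 1 to compound 4 from compound 1. Compound 4 is therefore estimated at 100000 nM, plausibly between 40000 nM and 300000 nM, and most likely again only a limit.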

Compound 4, half-maximal inhibitory concentration: > 60000 nM
Compound 4: a limit, no number; the forecaster's own chance of this, stated with the estimate: 85%; the middle value lies beyond the limit too.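

In this assay compound 4 gives > 60000 nM, which is a limit and not a number, and compound 1 also stands at a limit, so no step from compound 1 to compound 4 can be read: the limit of > 60000 nM in this assay, at which 2 of the 4 values shown sit.

The compounds shown leave open what prop-1-en-1-yl in place of vinyl does on the core of compound 1, and which difference between that core and the core of compound 3 matters in this assay.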